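A single group exchanged on compound 3

The source may hold more compounds than are shown below. What is called first, only, known or untested is meant among the compounds shown, and "the series" means these compounds.

Values measured in a functional assay on HCT-116 cells (Homo sapiens) for inhibition, read by sulforhodamine B assay, with a stated time of 48 h, tested at 50 uM; a lower number here means less inhibition of growth, a higher number more inhibition of growth at the concentration tested:
- compound 1 `COc1cc2c(cc1CCC(C)C)C(=O)C[C@@H](c1ccc(O)cc1)O2`: 77%
- compound 2 `COc1cc2c(cc1CC=C(C)C)C(=O)C[C@@H](c1ccc(Oc3ccc(F)cc3)cc1)O2`: 29%
- compound 3 `COc1ccc([C@@H]2C/C(=N/OCc3cn(-c4cccc(CO)c4)nn3)c3cc(CC=C(C)C)c(OC)cc3O2)cc1`: 27%

The three compounds do not form a tidy series, as they differ from one another in more than one place. In this assay, compound 3 gives 27%, within the scatter of compound 2 at 29%. Compound 3 lies well beneath compound 1, which reaches 77%.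

The next compound, compound 4 `COc1ccc([C@@H]2C/C(=N/OCc3cn(-c4cccnc4Cl)nn3)c3cc(CC=C(C)C)c(OC)cc3O2)cc1`, keeps the rest of compound 3 but has 2-chloropyridin-3-yl in place of 3-(hydroxymethyl)phenyl on an aromatic nitrogen of a five-membered aromatic ring with 3 nitrogen (2-chloropyridin-3-yl in place of 3-(hydroxymethyl)phenyl on an aromatic nitrogen). For the measured compounds named here, no measured pair isolates a change at this place, so the data give no direct guide to its effect. The expectation therefore stays anchored on compound 3 at 27%. In this assay, the expected result is a small upward move, a number 3 percentage points higher from compound 3 to compound 4 (within the scatter), that stays within the scatter. For compound 4 the estimated value is 30%, with an expected range from 15% to 50%.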

Compound 4, percent growth inhibition at one concentration: 47%
Compound 4: the middle estimate sits 17 percentage points below what was measured; measured number inside the range.
By their numbers in this assay, from the lowest: compounds 3 and 2 (each within the scatter of the next); then compound 4; then compound 1.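

With the rest of the molecule held fixed, 2-chloropyridin-3-yl in place of 3-(hydroxymethyl)phenyl on an aromatic nitrogen gives, in this assay, a number 20 percentage points higher from compound 3 to compound 4 (beyond the scatter). For the compounds shown here, this is the first pair to isolate a change at this place, and it shows that the group carried there can move growth inhibition beyond the usual scatter. The exchange swaps the carbon-only ring for one with a ring nitrogen, adds a chlorine and loses the hydroxymethyl group all at once, and no measurement at hand accounts for the step.

The compounds shown leave open which of these differences matters, since a plain phenyl, a pyridin-3-yl without chlorine or a 2-chlorophenyl at this place would separate them. Also open, as far as these compounds go, is how an aminomethyl group would compare with the hydroxymethyl group here.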